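Amide aryl swap on the core of compound 2

This account rests on a few compounds, and the source may have more. Where it says the series, first, only, none or still open, it means among the compounds named here.

Among the compounds with values here, compound 2 `CNC(=O)c1cccc(S(=O)(=O)Oc2ccc(-c3cncn3C3CCN(C(=O)c4ccc(Cl)c(C(F)(F)F)c4)CC3)cc2)c1` gives the lower of the two numbers so far in an assay on HEK293 cells for antagonist activity at P2X purinoceptor 7 (Homo sapiens), read by fluorescence, with a stated time of 2 h (a higher number here means a weaker inhibitor, a lower number a stronger inhibitor), at 112 nM; compound 1 `O=C(c1ccc(Cl)c(C(F)(F)F)c1)N1CCC(n2cncc2-c2ccc(OS(=O)(=O)c3cccc(Br)c3)cc2)CC1` sits at 896 nM, and the step of an 8.0-fold lower number from compound 1 to compound 2 (0.90 log units; beyond the scatter) changed only the sulfonate aryl substituent. Compound 3 `CNC(=O)c1cccc(S(=O)(=O)Oc2ccc(-c3cncn3C3CCN(C(=O)c4ccc([N+](=O)[O-])cc4)CC3)cc2)c1` differs from compound 2 elsewhere: 4-nitrophenyl in place of 4-chloro-3-(trifluoromethyl)phenyl on a carbonyl carbon. Within the data shown here, no measured step touches this carbonyl carbon, so the one known step does not bear on the change. The step of a 3.1-fold higher number from compound 2 to compound 3 (0.49 log units; beyond the scatter) is therefore an estimate made without a guide, allowed a wide range. For compound 3 the expected value in this assay is 350 nM, between 90 nM and 1500 nM.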

Compound 3, half-maximal inhibitory concentration: 62 nM
For compound 3 the middle estimate is 5.6-fold (0.75 log units) above the measured one, and the stated range ends above it.
By their numbers in this assay, from the lowest: compounds 3 and 2 (each within the scatter of the next); then compound 1.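

Read in this assay the swap of 4-chloro-3-(trifluoromethyl)phenyl for 4-nitrophenyl on the carbonyl carbon gives a 1.8-fold lower number from compound 2 to compound 3 (0.26 log units; within the scatter) and so shows that this position, unchanged in the earlier step, accepts both substituted phenyl groups. The chlorine and trifluoromethyl pair is therefore not required here to hold the number. No evidence on the origin of this result is at hand.

Open, as far as these compounds go, is whether the carbonyl carbon needs an aromatic ring at all, as a cyclohexyl group would test. Also open, from the compounds shown here alone, is how an amine or a carboxylic acid on the phenyl ring would read.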